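A few compounds are considered here, and "the series" means these few. Any claim that something is new, unique, unknown or untested is made for them only; others in the source may bear on it.

Measured in a functional assay on HCT-116 cells (Homo sapiens) for antiproliferative activity, read by MTT assay, with a stated time of 72 h; a higher number here means a weaker inhibitor, a lower number a stronger inhibitor:
- Compound 1 `O=C(CCc1cccc2c1B(O)OC2)Nc1nccs1`: > 100000 nM (a limit of the assay, not a number)
- Compound 2 `O=C(CCc1cccc2c1B(O)OC2)Nc1cccc(Br)c1`: 1400 nM
- Compound 3 `Cc1ccc(NC(=O)CCc2cccc3c2B(O)OC3)cc1Br`: 1200 nM

In this assay compound 2 has one numerical neighbour, and the step to it is a 1.2-fold lower number from compound 2 to compound 3 (0.07 log units; within the scatter). Compound 4 `O=C(CCc1cccc2c1B(O)OC2)Nc1cccc(-c2cccc(Cl)c2)c1` carries 3-chlorophenyl in place of bromo on an aromatic carbon, meta to a large group: 3-chlorophenyl in place of bromo on an aromatic carbon.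

Going by the values given here, no measured step makes this same change. The nearest in place is the methyl in place of hydrogen on an aromatic carbon, already given above as within the scatter. The other measured step, an at least 71-fold lower number from compound 1 to compound 2 (1.85 log units; beyond the scatter), exchanges the whole group on the amide-type nitrogen, and compound 4 keeps that phenyl ring, so a change of that size is not expected. The expected step is a 1.4-fold lower number from compound 2 to compound 4 (0.15 log units; within the scatter), with no firm direction. Among the compounds with values here, the range stays wide, as no measured step shows a ring entering at this place. For compound 4 the estimated value is 1000 nM, with an expected range of 250 nM to 5000 nM.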

Compound 4, half-maximal inhibitory concentration: 350 nM
Estimate against measurement, compound 4: 2.9-fold (0.46 log units) above, within the range that was stated.
By their numbers in this assay, from the lowest: compound 4; then compounds 3 and 2 (each within the scatter of the next). At a limit, above all of these: compound 1.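

In this assay, the aromatic carbon that carries bromo in compound 2, meta to a large group, also takes a whole six-membered aromatic ring, and the number still falls: the change to 3-chlorophenyl gives a 4.0-fold lower number from compound 2 to compound 4 (0.60 log units; beyond the scatter) in this series. Going by these compounds alone, the only earlier change on this phenyl ring, a 1.2-fold lower number from compound 2 to compound 3 (0.07 log units; within the scatter), was a single methyl at another place, so this is the first step on that ring to lie beyond the scatter. Nothing among the data shown gives a cause for this step.

Open, on these data alone, is whether the entering ring or its chlorine carries the step, which a plain phenyl at this place would separate. Also open, as far as these compounds go, is how an amine, a carboxylic acid or a longer chain on this same carbon would read.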